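The source may hold more compounds than are shown below. What is called first, only, known or untested is meant among the compounds shown, and "the series" means these compounds.

Series notes. Among the measured compounds shown here, in an assay on L cells for inhibition of Protein-serine O-palmitoleoyltransferase porcupine (Mus musculus), read by reporter gene assay, with a stated time of 24 h (a lower number here means that less compound is needed, a higher number that more compound is needed for the effect), compound 1 `O=C(CSc1nc2c(c(=O)n1-c1ccccc1)SCC2)Nc1ccc(-c2ccco2)cn1` gives 3.5 nM, the second highest of the three numbers measured so far. Compound 2 `O=C(CSc1nc2c(c(=O)n1-c1ccccc1)SCC2)Nc1ccc(-c2ccccc2)nc1` gives 0.3 nM in this assay, and compound 3 `O=C(CSc1nc2c(c(=O)n1-c1ccccc1)SCC2)Nc1nc2ccc(Cl)cc2s1` gives 40 nM; compound 1 sits between the two, with both gaps beyond the usual scatter. For the measured compounds named here, no single-point step between measured compounds is available, so any pattern across these three remains open.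

Compound 4 `O=C(CSc1nc2c(c(=O)n1-c1ccccc1)SCC2)Nc1ccc(-c2ccsc2)cn1` has not been measured. It differs from compound 1 by thiophen-3-yl in place of furan-2-yl on an aromatic carbon. With one five-membered aromatic ring replaced by another of like size, the expected step of no change at the digits printed from compound 1 to compound 4 (within the scatter) is none beyond the scatter. Compound 4 is therefore estimated at 3.5 nM in this assay, within a range of 1 nM to 12 nM.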

Compound 4, half-maximal effective concentration: 2 nM
The estimate for compound 4 lay 1.8-fold (0.24 log units) above the measured number; the range from low to high includes it.
By their numbers in this assay, from the lowest: compound 2; then compounds 4 and 1 (each within the scatter of the next); then compound 3.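

Among the compounds shown here, this is the first step read at a single place: in this assay, thiophen-3-yl in place of furan-2-yl gives a 1.8-fold lower number from compound 1 to compound 4 (0.24 log units; within the scatter), so on this aromatic carbon, para to a large group, one five-membered aromatic ring with one hetero atom can replace another without a step beyond the scatter. The exchange of oxygen for sulfur and the shift in ring attachment, taken together, leave the number within the scatter. No measurement at hand explains this result.

As far as these compounds go, whether the two changes would each leave the number unchanged on their own remains open. Also open, from the compounds shown here alone, is how an amine or a carboxylic acid in place of the ring on this carbon would read.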